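The source may hold more compounds than are shown below. What is called first, only, known or untested is meant among the compounds shown, and "the series" means these compounds.

Measured so far:
Compound 1, `COc1ccc(C(/C=C/c2ccc(Cl)cc2)=N/O)cc1`, 11500 nM
Compound 2, `COc1ccc(C(/C=C/c2ccccc2)=N/O)cc1`, 11800 nM
Compound 3, `Cc1ccc(C(/C=C/c2ccc(Cl)cc2)=N/O)cc1`, 11600 nM

In a functional assay (Mus musculus, strain Balb/c) for inhibition, read by ELISA, with a stated time of 72 h (on this read-out higher numbers stand for weaker inhibition and lower numbers for stronger inhibition), these three compounds sit close together. One change has already been made and measured: chloro in place of hydrogen on an aromatic carbon, which gave a 1.0-fold lower number from compound 2 to compound 1 (0.01 log units; within the scatter). The difference between the core of compound 3 and the core of compound 2 is not broken down here.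

Compound 4, `Cc1ccc(C(/C=C/c2ccc(Cl)c(Cl)c2)=N/O)cc1`, is not yet measured. It carries the same kind of change: chloro in place of hydrogen on an aromatic carbon. The surroundings differ, though: here the new group sits ortho to a chloro group and meta to a large group, whereas before it sat para to a large group.

Because the earlier step of a 1.0-fold lower number from compound 2 to compound 1 (0.01 log units; within the scatter) stayed within the scatter, compound 4 is expected to move by about a 1.0-fold higher number from compound 3 to compound 4 (0.01 log units; within the scatter). Compound 4 is therefore estimated at 12000 nM, with a range from 6000 nM to 24000 nM.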

Compound 4, half-maximal inhibitory concentration: 6340 nM
For compound 4 the middle estimate is 1.9-fold (0.28 log units) above the measured one; the measured number falls inside the stated range.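

In this assay, chloro in place of hydrogen on an aromatic carbon gives a 1.8-fold lower number from compound 3 to compound 4 (0.26 log units; within the scatter). Set beside the earlier step, the same change on a second core gives no difference that rises above the scatter: the same change on two cores in this assay, a 1.0-fold lower number (0.01 log units; within the scatter) from compound 2 to compound 1 and a 1.8-fold lower number (0.26 log units; within the scatter) from compound 3 to compound 4, 1.8-fold (0.25 log units) apart, within the scatter of two such steps Two steps in differing surroundings do not show that the change has no effect, nor that it would behave alike on any further core.

The compounds shown leave open what other groups on this ring, such as fluoro, nitrile or an amine, would do to the number. Also open, from the compounds shown here alone, is whether a carboxylic acid in place of the methyl of compound 3 would produce a step beyond the scatter.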